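This account rests on a few compounds, and the source may have more. Where it says the series, first, only, none or still open, it means among the compounds named here.

Compound 1 `CCCOc1ccc(NC(=O)CSc2nnc(Cc3nn(C)c(=O)c4ccccc34)n2C)cc1` and compound 2 `CC(C)Oc1ccc(NC(=O)CSc2nnc(Cc3nn(C)c(=O)c4ccccc34)n2C)cc1` share one core and differ only in the ether chain on the aromatic ring. In an assay on isolated protein (Mus musculus) for inhibition of IL15-IL15 receptor (Homo sapiens), read by resazurin assay, with stated times of 30 min and 2.5 days (on this read-out higher numbers stand for weaker inhibition and lower numbers for stronger inhibition), compound 1 gives > 30000 nM, which is a limit of the assay and not a number. Compound 2 likewise gives only the limit > 30000 nM in this assay. The step that the two limits leave unreadable from compound 1 to compound 2 is thus unreadable, as both values sit at the limit of > 30000 nM in this assay, at which 2 of the 2 values shown sit. Compound 3 `CC(C)COc1ccc(NC(=O)CSc2nnc(Cc3nn(C)c(=O)c4ccccc34)n2C)cc1` carries isobutyl in place of isopropyl on an oxygen on an aromatic ring. Among the compounds with values here, no measured step gives a size for this change, and compound 2 stands only at a limit. Compound 3 is therefore expected to remain at the limit as well, with an estimated 30000 nM (range 10000 nM to 100000 nM), an expected step of a number no higher from compound 2 to compound 3 (the limit leaves the size open).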

Compound 3, half-maximal inhibitory concentration: 30000 nM
Beside the measured number, compound 3's estimate shows no gap at the digits printed, and the stated range covers the measured number.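

In this assay, within the data shown here, compound 3, with isobutyl on an oxygen on an aromatic ring, gives 30000 nM, the first plain number at this position. Compound 2 gives > 30000 nM, which is a limit of the assay and not a number. This leaves a number no higher from compound 2 to compound 3 (the limit leaves the size open), and likewise a number no higher from compound 1 to compound 3 (the limit leaves the size open). The size of these steps therefore cannot be read, and most values stay at the limit: the limit of > 30000 nM in this assay, at which 2 of the 3 values shown sit.

From the compounds shown here alone, whether the isobutyl chain changes anything at all thus stays open. So does what a longer chain, an amine or a carboxylic acid on this oxygen would give in this assay.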